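The source may report more compounds than this note shows. Statements on the series, on what has been measured and on what is new or still open speak of the compounds shown alone.

Compound 3 `O=C(COc1cccc2ccccc12)N/N=C/c1ccccc1O` gives 5.19 ug/mL in an ADME assay on MT4 cells (Homo sapiens) for cytotoxicity, read by MTT assay, with a stated time of 4 days (a lower number here means that less compound is tolerated, a higher number that more compound is tolerated), the lowest of the three numbers; compound 2 `C/C(=N\NC(=O)COc1cccc2ccccc12)c1cccc([N+](=O)[O-])c1` gives 12.1 ug/mL, and compound 1 `O=C(COc1cccc2ccccc12)N/N=C/c1ccc(O)cc1` gives 26.5 ug/mL. Compound 4 `O=C(COc1cccc2ccccc12)N/N=C/c1cccc(Br)c1` carries 3-bromophenyl in place of 2-hydroxyphenyl on a carbon with a double bond to nitrogen. Among the compounds with values here, the only measured step at that position is a 5.1-fold lower number from compound 1 to compound 3 (0.71 log units; beyond the scatter); no measured step exchanges a hydroxyphenyl for a bromophenyl, so that step bears on the change only indirectly. The aryl changes seen so far have moved the number beyond the scatter in both directions. On that basis the number for compound 4 in this assay is expected to rise, a modest step of a 2.3-fold higher number from compound 3 to compound 4 (0.36 log units; beyond the scatter). The estimate for compound 4 is 12 ug/mL, with a range from 4 ug/mL to 35 ug/mL.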

Compound 4, half-maximal cytotoxic concentration: 87.4 ug/mL
The estimate for compound 4 lay 7.3-fold (0.86 log units) below the measured number; measured number outside the range, above it.
By their numbers in this assay, from the lowest: compound 3; then compound 2; then compound 1; then compound 4.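

In this assay, replacing either hydroxyphenyl with 3-bromophenyl on a carbon with a double bond to nitrogen raises the number: a 17-fold higher number from compound 3 to compound 4 (1.23 log units; beyond the scatter) and a 3.3-fold higher number from compound 1 to compound 4 (0.52 log units; beyond the scatter). The number at this position therefore depends on more than where the hydroxyl sits, and a ring without a hydroxyl can give a higher number than both hydroxyphenyl compounds. No evidence is available to explain this rise.

As far as these compounds go, whether it follows from gaining the bromine or from losing the hydroxyl remains open. It is also unknown how an amine or a carboxylic acid on this ring would behave.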